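This account rests on a few compounds, and the source may have more. Where it says the series, first, only, none or still open, it means among the compounds named here.

Three esters of the shared core are measured so far. Compound 1 `COC(=O)[C@@]1(O)C[C@@H](O)[C@H](OC(=O)/C=C/c2ccc(O)c(O)c2)[C@H](OC(=O)/C=C/c2ccc(O)c(O)c2)C1` gives 20200 nM in a functional assay on BV-2 cells (Mus musculus) for inhibition, read by Griess assay, with a stated time of 10 min; on this read-out lower numbers stand for stronger inhibition and higher numbers for weaker inhibition. Compound 2 `COC(=O)[C@]1(O)C[C@@H](O)[C@@H](OC(=O)/C=C/c2ccc(O)c(O)c2)[C@H](OC(=O)/C=C/c2ccc(O)c(O)c2)C1` gives 24600 nM in this assay; the two differ only in configuration as drawn (the fact that compounds 1 and 2 differ only in the configuration as drawn), and a 1.2-fold higher number from compound 1 to compound 2 (0.09 log units; within the scatter). Compound 3 `COC(=O)[C@]1(O)C[C@@H](O)[C@@H](OC(=O)/C=C/c2ccc(O)c(O)c2)[C@H](O)C1` carries one (2-(3,4-dihydroxyphenyl)ethenyl)carbonyl group fewer and gives 16600 nM in this assay; a 1.2-fold lower number from compound 1 to compound 3 (0.09 log units; within the scatter), and a 1.5-fold lower number from compound 2 to compound 3 (0.17 log units; within the scatter). On the numbers shown compound 3 has the lowest value of the three, yet its gaps to compound 1 and to compound 2 both lie within the scatter, so the three compounds cannot be separated.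

Compound 4 `COC(=O)[C@]1(O)C[C@@H](O)[C@@H](OC(=O)/C=C/c2ccc(O)cc2)[C@H](O)C1` is the next step from compound 3: hydrogen in place of hydroxy on an aromatic carbon, which, cut one bond further out, reads 3,4-dihydroxyphenyl to 4-hydroxyphenyl. Among the measured compounds shown here, no measured step touches this part of the molecule; the steps recorded concern configuration and the loss of a whole ester group, and all three fall within the scatter. No direction for the present change can be drawn from them, so the working expectation is a step no larger than the scatter, with somewhat more room toward a higher number than toward a lower one. Compound 4 is estimated at 24000 nM in this assay, with a range of 9000 nM to 65000 nM. This corresponds to an expected step of a 1.4-fold higher number from compound 3 to compound 4 (0.16 log units; within the scatter).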

Compound 4, half-maximal inhibitory concentration: 45000 nM
Compound 4: the middle estimate sits 1.9-fold (0.27 log units) below what was measured; measured number inside the range.
By their numbers in this assay, from the lowest: compounds 3, 1, 2 and 4 (each within the scatter of the next, the first and the last beyond it).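

Hydrogen in place of hydroxy on the aromatic carbon, which reads 3,4-dihydroxyphenyl to 4-hydroxyphenyl, is the first change in the series to give a step beyond the scatter in this assay: a 2.7-fold higher number from compound 3 to compound 4 (0.43 log units; beyond the scatter). Among the compounds shown here, the earlier steps, one in configuration and two in the loss of a whole (2-(3,4-dihydroxyphenyl)ethenyl)carbonyl group, all stayed within the scatter, so this aromatic position is the only place so far where a single change separates two values, although the step is modest and rests on one pair. Nothing among the data shown gives a cause for this step.

The compounds shown leave open whether a methoxy group, a fluorine atom or an amine at this position would read like the hydroxy group or like hydrogen, and what happens when the remaining hydroxy group of the 4-hydroxyphenyl group is replaced. They also leave open whether the same change gives a step of similar size in a compound carrying both ester groups, or in the other configuration as drawn.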